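Working notes on a small series at the assay limit

The source may report more compounds than this note shows. Statements on the series, on what has been measured and on what is new or still open speak of the compounds shown alone.

Measured so far:
compound 1 `C=CCn1ncc2c(C)nc(CC)n2c1=O` gives > 48000 nM, a limit of the assay.
compound 2 `CCCc1nc(C)c2c(C)nn(CC)c(=O)n12` gives > 48000 nM, a limit of the assay.
compound 3 `CCCc1nc(C)c2c(C)nn(CCC)c(=O)n12` gives > 48000 nM, a limit of the assay.

In a functional assay for inhibition, with Homo sapiens as the target (on this read-out higher numbers stand for weaker inhibition and lower numbers for stronger inhibition), no number has been reached for any of the three, and the same limit holds throughout: the limit of > 48000 nM in this assay, at which 3 of the 3 values shown sit. Compound 2 and compound 3 differ by methyl in place of hydrogen on a saturated chain carbon, two bonds along the chain from an aromatic nitrogen; the step that the two limits leave unreadable from compound 2 to compound 3. How the core of compound 1 differs from the core of compound 2 is not broken down here. Compound 4 `C=CCn1ncc2c(C)nc(C(C)C)n2c1=O` differs from compound 1 by methyl in place of hydrogen on a saturated chain carbon bound to an aromatic carbon and a saturated chain carbon. The place is not the same as in the change from compound 2 to compound 3, where the methyl enters on a saturated chain carbon two bonds along the chain from an aromatic nitrogen, so this is the same kind of change, not the same change. With the earlier step unreadable between two limits, the expected step that the limit leaves unreadable from compound 1 to compound 4 rests only on compound 1 sitting at the limit of > 48000 nM in this assay, at which 3 of the 3 values shown sit. Compound 4 is expected to give 70000 nM, estimated between 30000 nM and 300000 nM.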

Compound 4, half-maximal inhibitory concentration: > 48000 nM
Compound 4: only a limit was reported; the forecaster's own chance of this, stated with the estimate: 85%; the middle value does not contradict the limit.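

For the compounds shown here, compound 4 gives > 48000 nM, a limit of the assay, so no step from compound 1 to compound 4 can be read. The compounds shown leave open whether any change to these structures gives a number rather than a limit in this assay: the limit of > 48000 nM in this assay, at which 4 of the 4 values shown sit.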